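The compounds below may be only part of what the source reports. "The series", "measured", "known", "first", "only" and "open" are said of these compounds alone.

Compound 1 `C/N=C(/NC#N)NCCCCCCn1nc(-c2ccccc2)ccc1=O` was examined in a functional assay on the whole organism (stomach) with Rattus norvegicus as the target; a lower number here means that less compound is needed, a higher number that more compound is needed for the effect. Compound 1 gives only a limit there, > 100 mg/kg, not a number. Compound 2 `C/N=C(/NC#N)NCCCCn1nc(-c2ccccc2)c(C)cc1=O` likewise reaches only a limit, > 100 mg/kg. Compound 3 `C/N=C(/NC#N)NCCCCn1nc(-c2ccc(C)cc2)ccc1=O` also stops at a limit, > 100 mg/kg. Compound 1 thus stands where every measured compound stands, at the limit of > 100 mg/kg in this assay, at which 3 of the 3 values shown sit. Compound 4 `CC/N=C(\S)NCCCCCn1nc(-c2ccccc2)ccc1=O` differs from compound 1 in one place: a group of 6 heavy atoms (3 carbon, 2 nitrogen, 1 sulfur; no ring) in place of a group of 8 heavy atoms (4 carbon, 4 nitrogen; no ring), on a saturated chain carbon, five bonds along the chain from an aromatic nitrogen. For the measured compounds named here, no measured pair separates these two groups, so the three limits carry no information about the direction or size of such a change. The account expects no step beyond the scatter, a number no higher from compound 1 to compound 4 (the limit leaves the size open), with compound 4 most likely remaining at the limit as well. Compound 4 is estimated at 100 mg/kg, within a range from 30 mg/kg to 300 mg/kg.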

Compound 4, dose for half-maximal effect: 51.8 mg/kg
Beside the measured number, compound 4's estimate is 1.9-fold (0.29 log units) above it; measured number inside the range.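

The change at this place, on a saturated chain carbon, five bonds along the chain from an aromatic nitrogen, gives an at least 1.9-fold lower number from compound 1 to compound 4 (0.28 log units; that floor lies within the scatter). In this assay, compound 4 is the only compound shown that gives a number, and the rest stop at a limit: the limit of > 100 mg/kg in this assay, at which 3 of the 4 values shown sit.

Going by these compounds, the true size of the step stays open, since compound 1 gives only a limit and the step may or may not exceed the scatter. Also open, on these data alone, is how an amine or a carboxylic acid at this place would compare with compound 4.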